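The source may hold more compounds than are shown below. What is called first, only, known or untested is meant among the compounds shown, and "the series" means these compounds.

Compounds 1, 2 and 3 share one core and differ only in a single group attached to it. Compound 1, `C#CC[C@@H]1O[C@H](COCc2ccccc2)[C@@H](OCc2ccccc2)[C@H](OCc2ccccc2)[C@H]1O`, gives "not active" (no number reported) in a functional assay on HL-60 cells (Homo sapiens) for antiproliferative activity, read by MTT assay (a lower number here means a stronger inhibitor, a higher number a weaker inhibitor), so no number stands for it. Compound 2, `CCC[C@@H]1O[C@H](COCc2ccccc2)[C@@H](OCc2ccccc2)[C@H](OCc2ccccc2)[C@H]1O`, gives 11700 nM in this assay. Compound 3, `CCC[C@H]1O[C@H](COCc2ccccc2)[C@@H](OCc2ccccc2)[C@H](OCc2ccccc2)[C@H]1O`, gives 28200 nM in this assay. Of the two numbers at hand, compound 2 has the lower one: the step of a 2.4-fold higher number from compound 2 to compound 3 (0.38 log units; beyond the scatter) is modest, and all that stands behind it is the fact that compounds 2 and 3 differ only in the configuration as drawn.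

Compound 4, `O[C@@H]1[C@@H](OCc2ccccc2)[C@H](OCc2ccccc2)[C@@H](COCc2ccccc2)O[C@H]1CC1CC1`, has not yet been measured. It differs from compound 2 by cyclopropyl in place of ethyl on a saturated chain carbon bound to a saturated ring carbon; seen one bond further out, the group on the shared core goes from propyl to cyclopropylmethyl. Among the compounds with values here, no measured pair makes the same change, so nothing here sets the size of the step directly. Within the data shown here, the only measured step, a 2.4-fold higher number from compound 2 to compound 3 (0.38 log units; beyond the scatter), alters just the drawn configuration and says little about a change of this kind. Compound 1 being inactive while compound 2 gives a number shows that this group can matter, but not which way a cyclopropyl will pull. The expectation is therefore a step of a 1.0-fold higher number from compound 2 to compound 4 (0.01 log units; within the scatter) staying within the scatter, so that compound 4 is estimated to give 12000 nM in this assay, within a range from 5000 nM to 30000 nM.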

Compound 4, half-maximal inhibitory concentration: "not active" (no number reported)
Nothing numeric was reported for compound 4; there is nothing to compare the estimate with.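

Within the data shown here, compound 4, like compound 1, has no reported number, so no step from compound 2 to compound 4 or between any other pair involving them can be read. The compounds shown leave open how large the change from propyl to cyclopropylmethyl on the shared core is. Nothing available here bears on this result.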